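The source may report more compounds than this note shows. Statements on the series, on what has been measured and on what is new or still open speak of the compounds shown alone.

Compound 1 `N#Cc1ccc(N2CC[C@@H](NC(=O)Nc3ccccc3Br)C2)nc1`: in a functional assay for antagonist activity at transient receptor potential cation channel subfamily V member 1 (Rattus norvegicus), read by FLIPR (on this read-out lower numbers stand for lower potency and higher numbers for higher potency (the scale is a negative logarithm)), compound 1 gives 6.7.
Compound 2 `Cc1ccc(N2CC[C@@H](NC(=O)Nc3ccccc3Br)C2)nc1`: in this assay compound 2 reaches only a limit of the assay, reported as < 6.7.

Compound 2 therefore stands not at a number but at the limit of the assay, the one marked as the limit of < 6.7 in this assay, at which 1 of the 2 values shown sits. Among the measured compounds shown here, the single measured step, a number no higher from compound 1 to compound 2 (the limit leaves the size open), runs downward, yet its size cannot be read because compound 2 sits at the limit of < 6.7 in this assay, at which 1 of the 2 values shown sits. Compound 3 `O=C(Nc1ccccc1Br)N[C@@H]1CCN(c2ccc(Cl)cn2)C1` has not been measured. It differs from compound 2 in one place: chloro in place of methyl on an aromatic carbon. For the measured compounds named here, no measured step swaps chloro for methyl, so the only guide is the pair of compound 1 and compound 2 at this same position, where cyano gave a number and methyl fell to the limit. Compound 3 is expected to land near the region where compound 1 stands, with an estimate of 6.5 and a range from 5.8 to 7.2. Going by these compounds, that estimate means an expected step that the limit leaves unreadable from compound 2 to compound 3 upward from the limit, and its size stays open because compound 2 sits at the limit of < 6.7 in this assay, at which 1 of the 2 values shown sits.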

Compound 3, negative logarithm of the antagonist equilibrium constant: 7.3
Compound 3: the middle estimate sits 0.80 log units below what was measured; the measured number lies above the stated range.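

Compound 3 shows that the group on this aromatic carbon, para to a large group, can move potency upward even when a single heavy atom is exchanged: putting chloro in place of methyl gives a number at least 0.60 log units higher from compound 2 to compound 3 (beyond the scatter) in this assay. It also shows that the cyano of compound 1 is not the best group seen here, since chloro in place of cyano gives a number 0.60 log units higher from compound 1 to compound 3 (beyond the scatter), and the 5-chloropyridin-2-yl compound now holds the highest number of the three. The size of the step from methyl to chloro has only a lower bound, and the step from cyano to methyl still cannot be read, because compound 2 stands at a limit of the assay rather than at a number: the limit of < 6.7 in this assay, at which 1 of the 3 values shown sits.

The compounds shown leave open whether fluoro, methoxy or an amine on this same carbon would match or pass chloro, and they give no measured reason for the order seen among the three groups. They also leave open whether chloro would keep its lead over cyano if the bromine elsewhere in the shared core were replaced.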